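From phenyl to thiophen-3-yl: the step to compound 4

The source may hold more compounds than are shown below. What is called first, only, known or untested is meant among the compounds shown, and "the series" means these compounds.

Measured in a functional assay on SNB-19 cells (Homo sapiens) for inhibition, read by MTT assay, with a stated time of 7 days; on this read-out higher numbers stand for weaker inhibition of growth and lower numbers for stronger inhibition of growth:
Compound 1 `C#CCn1nnc2c(C(N)=O)ncn2c1=O`: 35600 nM
Compound 2 `NC(=O)c1ncn2c(=O)n(Cc3ccsc3)nnc12`: > 50000 nM
Compound 3 `NC(=O)c1nc[nH]c1N/N=N/Cc1ccccc1`: > 50000 nM

Compound 3 gives > 50000 nM, which is a limit of the assay and not a number. Compound 2 gives > 50000 nM, which is also a limit. The picture is therefore thin: the limit of > 50000 nM in this assay, at which 2 of the 3 values shown sit. Only compound 1 has a true number, 35600 nM.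

Compound 4 `NC(=O)c1nc[nH]c1N/N=N/Cc1ccsc1` differs from compound 3 in one place: thiophen-3-yl in place of phenyl on a saturated chain carbon bound to a double-bonded nitrogen. In words, this is thiophen-3-yl in place of phenyl on a saturated chain carbon bound to a double-bonded nitrogen.

Within the data shown here, no measured step makes this exact swap. The nearest is an at least 1.4-fold higher number from compound 1 to compound 2 (0.14 log units; that floor lies within the scatter), where thiophen-3-yl replaces ethynyl on a saturated chain carbon bound to an aromatic nitrogen. That step starts from a different group on the core of compound 1, and its floor lies within the scatter. On that basis, no step beyond the scatter is expected in this assay, and another limit is the likeliest report. The expected step is a step that the limit leaves unreadable from compound 3 to compound 4. For compound 4 the estimated value is 60000 nM, with an expected range of 30000 nM to 120000 nM.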

Compound 4, concentration for 50% growth inhibition: > 50000 nM
Compound 4: a limit, no number; the forecaster's own chance of this, stated with the estimate: 80%; the middle value is on the limit's open side.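

In this assay compound 4 gives > 50000 nM as a limit and not a number. No step can be read from compound 3 to compound 4, because both rest on the same limit: the limit of > 50000 nM in this assay, at which 3 of the 4 values shown sit. Whether thiophen-3-yl in place of phenyl changes inhibition of growth at all stays open in the compounds shown.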